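This account rests on a few compounds, and the source may have more. Where it says the series, first, only, none or still open, it means among the compounds named here.

Of the compounds shown here, three have so far been measured in an ADME assay on RD cells (Homo sapiens) for cytotoxicity, read by MTT assay, with a stated time of 3 days; on this read-out lower numbers stand for higher toxicity in this test and higher numbers for lower toxicity in this test. Compound 1 `CC[C@@H](CCn1cncn1)c1ccc(Cl)cc1` gives 55.3 ug/mL. Compound 2 `CC[C@@H](CCn1cncn1)c1ccc(C)cc1` differs from compound 1 by one change only, (methyl in place of chloro on an aromatic carbon). In this test compound 2 gives 79.4 ug/mL, so that the step reads a 1.4-fold higher number from compound 1 to compound 2 (0.16 log units; within the scatter). Compound 3 `Clc1ccc([C@@H](CCn2cncn2)Cc2ccccc2)cc1` is built on a different core, and the difference between the two cores is not broken down here. In this test compound 3 gives 24.4 ug/mL, the lowest of the three numbers, and its gaps to compound 1 and to compound 2 both lie beyond the usual scatter of repeated measurements.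

Compound 4 `Cc1ccc([C@@H](CCn2cncn2)Cc2ccccc2)cc1` has not yet been measured. It is related to compound 3 by methyl in place of chloro on an aromatic carbon, the same change that leads from compound 1 to compound 2, and in both pairs the place of the change is described in the same words. Among the compounds with values here, that single measured example is the only guide to how the change acts, and it moved the number only a little. Within the data shown here, the step from compound 3 to compound 4 is expected to be a 1.3-fold higher number from compound 3 to compound 4 (0.12 log units; within the scatter), because the one measured example of this change gave a 1.4-fold higher number from compound 1 to compound 2 (0.16 log units; within the scatter). Compound 4 is therefore estimated to give 32 ug/mL in this test, with a likely range from 18 ug/mL to 60 ug/mL.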

Compound 4, half-maximal cytotoxic concentration: 109 ug/mL
Estimate against measurement, compound 4: 3.4-fold (0.53 log units) below, outside the stated range (above it).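

On the core of compound 3, putting methyl in place of chloro gives a 4.5-fold higher number from compound 3 to compound 4 (0.65 log units; beyond the scatter) in this assay, a clear move toward lower toxicity in this test, whereas the same swap on the core of compound 1 stayed inside the normal noise of the measurement. Set side by side, the two steps differ by more than repeated measurements would explain: the same change on two cores in this assay, a 1.4-fold higher number (0.16 log units; within the scatter) from compound 1 to compound 2 and a 4.5-fold higher number (0.65 log units; beyond the scatter) from compound 3 to compound 4, 3.1-fold (0.49 log units) apart, beyond the scatter of two such steps This shows that the size of this step cannot simply be carried from one core to the next in this series, but with only two pairs it does not show which feature of the cores makes the difference, or how the swap would turn out on a third core.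

The compounds shown leave open whether another group at the same place, such as fluoro, methoxy or a carboxylic acid, would also behave differently on the two cores. They also leave open whether a core bearing a longer chain would follow the step seen on compound 1, the step seen on compound 3, or neither.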